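Swapping a Propyl Amide for a 4-Fluorobenzamide

The compounds below may be only part of what the source reports. "The series", "measured", "known", "first", "only" and "open" are said of these compounds alone.

Compound 3 `CCCC(=O)Nc1cccc(NC(=O)COc2ccc3c(=O)ccoc3c2)c1` stands highest of the two numbers in an assay on isolated protein for inhibition of Rho-associated protein kinase 1 (Homo sapiens), read by scintillation counting, radiometric assay and 33P incorporation, with a stated time of 40 min, in the presence of a further agent that is not named here (on this read-out higher numbers stand for weaker inhibition and lower numbers for stronger inhibition), where compound 3 gives 1430 nM. Compound 2 `CN(C)c1ccc(C(=O)Nc2cccc(NC(=O)COc3ccc4c(c3)OCCC4=O)c2)cc1` gives 144 nM. Compound 1 `COc1ccc(OCC(=O)Nc2cccc(NC(=O)c3ccc(N(C)C)cc3)c2)cc1OC` gives only a limit of the assay, > 10000 nM; this is the limit of > 10000 nM in this assay, at which 1 of the 3 values shown sits. Going by the values given here, the single measured step, an at least 69-fold lower number from compound 1 to compound 2 (1.84 log units; beyond the scatter), alters the group on the ether oxygen, not the amide end, so it does not bear directly on the change considered here. Compound 4 `O=C(COc1ccc2c(=O)ccoc2c1)Nc1cccc(NC(=O)c2ccc(F)cc2)c1` differs from compound 3 by 4-fluorophenyl in place of propyl on a carbonyl carbon. Compound 2 also carries a six-membered aromatic ring on that carbonyl carbon and gives 144 nM, which hints at a lower number for compound 4. Compound 4 is expected to give 400 nM, between 120 nM and 1500 nM. The estimated step is a 3.6-fold lower number from compound 3 to compound 4 (0.55 log units; beyond the scatter).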

Compound 4, half-maximal inhibitory concentration: 129 nM
Estimate against measurement, compound 4: 3.1-fold (0.49 log units) above, and the stated range covers the measured number.
By their numbers in this assay, from the lowest: compounds 4 and 2 (each within the scatter of the next); then compound 3. At a limit, above all of these: compound 1.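

On the carbonyl carbon whose other neighbour is the amide-type nitrogen, 4-fluorophenyl in place of propyl brings a large gain in inhibition (an 11-fold lower number from compound 3 to compound 4 (1.04 log units; beyond the scatter)). The earlier step changed only the group on the ether oxygen, so this is the only measured view of the amide end. Nothing measured here explains the size of this step. Still open, from the compounds shown here alone, is how a plain phenyl or a longer chain on this carbonyl carbon would compare, and whether the fluorine contributes anything to the gain.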